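Replacing the Amide Arm of Compound 3 with an Amine

A few compounds are considered here, and "the series" means these few. Any claim that something is new, unique, unknown or untested is made for them only; others in the source may bear on it.

Measured compounds:
compound 1, `CNC(=O)/C=C1/COc2cc(OCc3cccc(Cl)c3)ccc21`, 36 nM
compound 2, `CNC(=O)Cc1coc2cc(OCc3cccc(Cl)c3)ccc12`, 284 nM
compound 3, `CNC(=O)Cc1cc(=O)oc2cc(OS(=O)(=O)c3cccc(Cl)c3)ccc12`, 8300 nM

All three were tested in an assay (strain Sprague-Dawley) for inhibition of Amine oxidase [flavin-containing] B (Rattus norvegicus), read by spectrophotometry, with a stated time of 5 min; a lower number here means a stronger inhibitor, a higher number a weaker inhibitor. Compound 3 stands highest of the three numbers: its nearest neighbour, compound 2, lies well beyond the scatter below it, and compound 1 further still. Compound 4, `CNCc1cc(=O)oc2cc(OS(=O)(=O)c3cccc(Cl)c3)ccc12`, is not yet measured. It differs from compound 3 by methylamino in place of methylcarbamoyl on a saturated chain carbon bound to an aromatic carbon. Going by the values given here, no measured pair isolates this change, so the direction rests on judgement. Compound 4 is expected to stay roughly where compound 3 stands, with the step of a 2.1-fold lower number from compound 3 to compound 4 (0.32 log units; beyond the scatter) likely within or only slightly beyond the scatter. The value of compound 4 in this assay is estimated at 4000 nM, with a range from 800 nM to 20000 nM.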

Compound 4, half-maximal inhibitory concentration: 1700 nM
Estimate against measurement, compound 4: 2.4-fold (0.37 log units) above; the range from low to high includes it.
By their numbers in this assay, from the lowest: compound 1; then compound 2; then compound 4; then compound 3.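

In this assay, going by these compounds alone, methylamino in place of methylcarbamoyl gives a 4.9-fold lower number from compound 3 to compound 4 (0.69 log units; beyond the scatter), the only step here that isolates a single change at this position. It shows that the methylcarbamoyl group is not needed for inhibition on this core, and that the smaller methylamino group, which lacks the carbonyl, gives a modest gain. Nothing available accounts for this gain.

As far as these compounds go, it remains open whether a longer chain ending in methylamino, or a dimethylamino group, would move the number further. From the compounds shown here alone, the same change on the cores of compound 1 and compound 2 also remains untested by these data.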